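Series notes: the step from compound 2 to compound 4

The compounds below may be only part of what the source reports. "The series", "measured", "known", "first", "only" and "open" are said of these compounds alone.

Measured so far in an assay on isolated protein for inhibition of ribosomal protein S6 kinase beta-1 (Homo sapiens), read by HTRF, tested at 10 uM; on this read-out higher numbers stand for more inhibition at the one concentration tested (going by the name of the read-out) and lower numbers for less inhibition:
compound 1 `Cc1cccc(Nc2ncnc3c2CN(C(=O)c2ccc(N(C)C)c4ccccc24)CC3)c1`: 0%
compound 2 `Clc1ccc2sc(CN3CCN(c4ncnc5c4CN(Cc4ccccc4)CC5)CC3)cc2c1`: 11%
compound 3 `O=C(CN1CCN(c2ncnc3c2CN(Cc2ccccc2)CC3)CC1)Nc1cc(F)ccc1F`: 8%

All three numbers are small. Compound 2 stands highest of the three. Compound 3 is nearest: the step of a number 3 percentage points lower from compound 2 to compound 3 (within the scatter) lies within the usual scatter, so the two cannot be ordered. Compound 1 stands furthest from compound 2, and that gap is the only one among the three that exceeds the scatter.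

Compound 4 `Cc1cc(C(=O)N2CCN(c3ncnc4c3CN(Cc3ccccc3)CC4)CC2)c(C)n1C` is not yet measured. Its difference from compound 2 is (1,2,5-trimethyl-1H-pyrrol-3-yl)carbonyl in place of (5-chloro-1-benzothiophen-2-yl)methyl on an amine nitrogen in a ring.

Among the compounds with values here, only one measured step bears on this change: the exchange of the group on the same ring region, a number 3 percentage points lower from compound 2 to compound 3 (within the scatter), which left the read-out essentially unchanged. Within the data shown here, no measured pair introduces a carbonyl directly on that ring nitrogen, and the lowest number of the set, from compound 1, comes from a structure not connected to compound 2 by any single step. Among the measured compounds shown here, with the one relevant step within the scatter, the expected step of a number 5 percentage points lower from compound 2 to compound 4 (within the scatter) is none beyond the scatter, if anything slightly downward. Compound 4 is therefore estimated at 6%, within -4% to 16%.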

Compound 4, a percentage reported as inhibition, at one concentration (the size of the read-out at that concentration, not a potency): 7%
Estimate against measurement, compound 4: 1 percentage points below, within the range that was stated.
By their numbers in this assay, from the lowest: compounds 1, 4, 3 and 2 (each within the scatter of the next, the first and the last beyond it).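

In this assay, the new step, a number 4 percentage points lower from compound 2 to compound 4 (within the scatter), places a carbonyl instead of a saturated carbon directly on the amine nitrogen in a ring, and it also removes the six-membered aromatic ring of carbon only, the sulfur and the chlorine, yet the read-out does not separate the two compounds. Within the data shown here, the earlier step, a number 3 percentage points lower from compound 2 to compound 3 (within the scatter), kept a saturated chain carbon on that nitrogen and exchanged only what this carbon carries, so the new step is the first reading on a change of the atom bound to the nitrogen itself, and both steps from compound 2 stay within the scatter. The data give no explanation for this flat result.

As far as these compounds go, it remains open whether any group on this nitrogen can lift this assay beyond the scatter from compound 2, for example a carboxylic acid or a longer chain ending in an amine. The compounds shown also leave open whether the group on the other ring nitrogen of the shared core matters, since compound 2, compound 3 and compound 4 all carry the same one there.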